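The source may report more compounds than this note shows. Statements on the series, on what has been measured and on what is new or still open speak of the compounds shown alone.

The three measured compounds share a core, and compound 1 `Cc1cc(C)c(S(=O)(=O)N2CCC(N3CCC(c4ccccc4)CC3)CC2)c(C)c1` serves as the starting point. In a functional assay on DLD-1 cells (Homo sapiens) for antiproliferative activity, read by CellTiter-Glo, with a stated time of 72 h (on this read-out higher numbers stand for weaker inhibition and lower numbers for stronger inhibition), compound 1 gives 865 nM. Two companions differ from compound 1 in more than one place: compound 2 `CC1CCN(C2CCN(S(=O)(=O)c3cccc(-c4ccc(Cl)cc4)c3)CC2)CC1` gives 15 nM and compound 3 `CC1CCN(C2CCN(S(=O)(=O)c3cccc(-c4ccccc4C(F)(F)F)c3)CC2)CC1` gives 10 nM. Compound 1 has the highest number of the three, and its distance to each companion lies well beyond the scatter, so compound 1 is the weakest inhibitor of this small set. Among the compounds with values here, the only change measured on its own, a 1.5-fold lower number from compound 2 to compound 3 (0.18 log units; within the scatter), concerns the aromatic part of the core and stays within the scatter.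

Compound 4 `Cc1cc(C)c(S(=O)(=O)N2CCC(N3CCCCC3)CC2)c(C)c1` differs from compound 1 in one place: hydrogen in place of phenyl on a saturated ring carbon. Within the data shown here, no measured step touches that position. Compounds 2 and 3 carry a different group at the same place but also differ from compound 1 elsewhere, so their two values alone cannot separate the two changes. Among the measured compounds shown here, with no direct precedent, the expectation rests on compound 1 and carries a wide range. Compound 4 is therefore expected to give 1500 nM, between 300 nM and 7500 nM, an estimated 1.7-fold higher number from compound 1 to compound 4 (0.24 log units; within the scatter) that may well fall inside the scatter.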

Compound 4, half-maximal inhibitory concentration: 2200 nM
For compound 4 the middle estimate is 1.5-fold (0.17 log units) below the measured one, and the stated range covers the measured number.
By their numbers in this assay, from the lowest: compounds 3 and 2 (each within the scatter of the next); then compound 1; then compound 4.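

Taking the phenyl off this saturated ring carbon, three ring bonds from the ring nitrogen, gives the first direct reading of the position: in this assay the change is a 2.5-fold higher number from compound 1 to compound 4 (0.41 log units; beyond the scatter), a step of modest size. On this one pair the phenyl therefore goes with somewhat stronger inhibition, yet it is not essential for activity, since compound 4, with only hydrogen at that carbon, still gives a measurable 2200 nM. No separate measurement bears on what lies behind this shift in the number.

Going by these compounds, with only hydrogen and phenyl compared directly on this core, it remains open how a hydroxyl group, an amine, a carboxylic acid or a benzyl group at the same carbon would behave, and so whether the number follows the size of the group or depends on the aromatic ring itself. On these data alone, it is also open whether removing the group at this carbon would cost as little when the sulfonyl group carries the aromatic parts found in compound 2 and compound 3.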